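This account rests on a few compounds, and the source may have more. Where it says the series, first, only, none or still open, it means among the compounds named here.

Compound 1 `CO[C@@H]1C/C=C(\C)C(=O)N(C)[C@@H](C(C)C)C(=O)N[C@H](Cc2ccccc2)C(=O)N[C@@H](C(C)C)C(=O)O[C@H](c2ccccc2)[C@H](C)/C=C/C=C/1C` and compound 2 `CO[C@@H]1C/C=C(\C)C(=O)N(C)[C@@H](C(C)C)C(=O)N[C@H](Cc2ccccc2)C(=O)N[C@@H](C(C)C)C(=O)O[C@H](c2ccccc2)C/C=C/C=C/1C` share a core that compound 3 `CC[C@H](C)[C@H]1C(=O)N[C@H](Cc2cc(Cl)c(O)c(Cl)c2)C(=O)N[C@@H](C(C)(C)O)C(=O)O[C@H](c2ccccc2)[C@H](C)/C=C/C=C(\C)[C@H](OC)C[C@@H]2O[C@@]2(C)C(=O)N1C` carries in altered form; how the two cores differ is not broken down here. In a functional assay on HCT-116 cells (Homo sapiens) for antiproliferative activity, read by MTT assay, with a stated time of 72 h (on this read-out lower numbers stand for stronger inhibition and higher numbers for weaker inhibition), compound 1 reaches only a limit, > 100 nM. Compound 2 likewise gives only a limit in this assay, > 100 nM. The step that the two limits leave unreadable from compound 1 to compound 2 is therefore unreadable, because the limit of > 100 nM in this assay, at which 2 of the 3 values shown sit, holds both of its ends. The change hydrogen in place of methyl on a saturated ring carbon recurs as hydrogen in place of methyl on a saturated ring carbon, leading from compound 3 to compound 4 `CC[C@H](C)[C@H]1C(=O)N[C@H](Cc2cc(Cl)c(O)c(Cl)c2)C(=O)N[C@@H](C(C)(C)O)C(=O)O[C@H](c2ccccc2)C/C=C/C=C(\C)[C@H](OC)C[C@@H]2O[C@@]2(C)C(=O)N1C`; the surroundings are not identical, as the ring of compound 4 is part of a fused or bridged system of two rings and bears a 1-hydroxy-1-methylethyl group, a sec-butyl group and a 3,5-dichloro-4-hydroxybenzyl group where compound 1 bears an isopropyl group, an isopropyl group and a benzyl group, so this is the same kind of change, not the same. In this assay compound 3 gives 17 nM. The step of a 2.4-fold higher number from compound 3 to compound 4 (0.37 log units; beyond the scatter) is expected to be modest, as the measured step that the two limits leave unreadable from compound 1 to compound 2 offers no readable size to rest on. Compound 4 is estimated at 40 nM, between 10 nM and 200 nM.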

Compound 4, half-maximal inhibitory concentration: 78.2 nM
Beside the measured number, compound 4's estimate is 2.0-fold (0.29 log units) below it; the measured number falls inside the stated range.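

Hydrogen in place of methyl on a saturated ring carbon gives a 4.6-fold higher number from compound 3 to compound 4 (0.66 log units; beyond the scatter) in this assay, so on this core the compound that keeps the methyl inhibits more strongly. For the compounds shown here, the same change on the core shared by compound 1 and compound 2 cannot be read, because both compounds sit at a limit: the limit of > 100 nM in this assay, at which 2 of the 4 values shown sit. Only one readable step therefore exists, and it shows neither the size nor the direction of the change on the other core.

The compounds shown leave open how an ethyl group or a hydroxymethyl group at that ring carbon would compare with methyl and hydrogen. They also leave open which of the groups that differ between the cores, such as the 3,5-dichloro-4-hydroxybenzyl group, separates compound 3 and compound 4 from the limit.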